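Benzyloxy in place of methoxy on the outer ether

The compounds below may be only part of what the source reports. "The series", "measured", "known", "first", "only" and "open" are said of these compounds alone.

Among the compounds with values here, compound 1 `COc1cc(OCc2ccccc2OC)c2cc(-c3cn4nc(OC)sc4n3)oc2c1` is the only member of this set with a number: in an ADME assay on microsomes from liver (Rattus norvegicus) for metabolic stability, with a stated time of 10 min (a higher number here means that more of the compound is left, a lower number that less of the compound is left), compound 1 gives 28%. Compound 2 `c1ccc(Sc2nn3cc(-c4cc5ccccc5o4)nc3s2)cc1` stands without a result, since in this assay compound 2 gives "not determined" (no result reported). Compound 3 `COc1cc(OCc2ccccc2OCc2ccccc2)c2cc(-c3cn4nc(OC)sc4n3)oc2c1` differs from compound 1 by phenyl in place of hydrogen on a saturated chain carbon bound to an oxygen on an aromatic ring. Within the data shown here, no measured step covers this change, so only compound 1 anchors the expectation. A modest downward step is expected, probably beyond the usual scatter but not by much. For compound 3 the estimated value in this assay is 17%, with a range from 5% to 32%. The expected step is a number 11 percentage points lower from compound 1 to compound 3 (beyond the scatter).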

Compound 3, percent of the compound remaining: 22%
Compound 3: middle estimate off by 5 percentage points, on the low side, within the range that was stated.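

In this assay, within the data shown here, methoxy to benzyloxy, with phenyl in place of hydrogen on a saturated chain carbon bound to an oxygen on an aromatic ring, gives a number 6 percentage points lower from compound 1 to compound 3 (within the scatter) and so adds the first reading of a change at this place. A group as large as phenyl can enter here without a step beyond the scatter, which compound 1 alone could not show. Nothing measured in this set bears on the reason for this result.

From the compounds shown here alone, whether a longer chain, an amine or a carboxylic acid in place of the phenyl would stay as close to compound 1 remains open. This single step also says nothing about changes elsewhere on the shared core.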